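The compounds below may be only part of what the source reports. "The series", "measured", "known", "first", "only" and "open" are said of these compounds alone.

The series shares one core and differs only in the chain carried on the aromatic nitrogen. Compound 1 `COCCOCn1cc[n+](C)c1/C=N/O` gives -2.81 in a physicochemical assay for lipophilicity; a higher number here means a more lipophilic compound, a lower number a more polar compound. Compound 2 `C[n+]1ccn(CC[N+](=O)[O-])c1/C=N/O` gives no result reported in this assay. Compound 3 `C[n+]1ccn(CCS(C)(=O)=O)c1/C=N/O` gives -3.5 in this assay, the lowest of the two numbers, with compound 1 the nearest above it. Among the measured compounds shown here, the one measured step that bears on this position is a number 0.69 log units lower from compound 1 to compound 3 (beyond the scatter). Compound 4 `CN(C)CCn1cc[n+](C)c1/C=N/O` differs from compound 3 by dimethylamino in place of methylsulfonyl on a saturated chain carbon, two bonds along the chain from an aromatic nitrogen. For the measured compounds named here, that earlier step shows only how far one swap of this chain moved this assay; no measured pair contains a dimethylamino group. On that basis the estimated step is a number 0.30 log units higher from compound 3 to compound 4 (within the scatter), a modest rise, smaller than the earlier step. Compound 4 is expected to read -3.2, within -4 to -2.4.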

Compound 4, distribution coefficient: -3.06
The estimate for compound 4 lay 0.14 log units below the measured number, and the stated range covers the measured number.
By their numbers in this assay, from the lowest: compound 3; then compounds 4 and 1 (each within the scatter of the next).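

Dimethylamino in place of methylsulfonyl gives a number 0.44 log units higher from compound 3 to compound 4 (beyond the scatter) in this assay and so separates these two chain ends by more than the scatter. The second step, a number 0.25 log units lower from compound 1 to compound 4 (within the scatter) in the same read-out, means the (dimethylamino)methyl and 2-methoxyethoxy chains cannot be told apart here. Nothing on hand explains either step. On these data alone, whether a carboxylic acid at this chain end would read with compound 3 or with compound 4 remains open. So does the effect of a longer chain carrying the dimethylamino group.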